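Swapping the ring on the chain: from hydantoin to thiazolidinedione

This account rests on a few compounds, and the source may have more. Where it says the series, first, only, none or still open, it means among the compounds named here.

Measured compounds in an ADME assay on microsomes from liver (Homo sapiens) for metabolic stability; on this read-out lower numbers stand for a shorter-lived compound and higher numbers for a longer-lived compound:
compound 1, `CC(C)[C@@H](C[C@H]1SC(=O)NC1=O)c1ccc(-c2ccc3cccc(F)c3c2)[nH]c1=O`: 1.24 h
compound 2, `C/C(=C1/OC(=O)NC1=O)C(c1ccc(-c2ccc3cccc(F)c3c2)[nH]c1=O)C(C)C`: > 3 h
compound 3, `CC(C)C(c1ccc(-c2ccc3cccc(F)c3c2)[nH]c1=O)C1C(=O)NC(=O)N1C`: 0.375 h

Compound 2 sits at a limit of this assay; its value is not a number. Compound 3 stands lowest of the two numbers shown, and compound 1 is the nearest to it with a higher number. Compound 4, `CC(C)C(c1ccc(-c2ccc3cccc(F)c3c2)[nH]c1=O)C1SC(=O)NC1=O`, differs from compound 3 in one place: 2,4-dioxo-1,3-thiazolidin-5-yl in place of 3-methyl-2,5-dioxoimidazolidin-4-yl on a saturated chain carbon bound to an aromatic carbon and a saturated chain carbon.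

Among the compounds with values here, one measured step bears on this change. The step of an at least 8.0-fold lower number from compound 2 to compound 3 (0.90 log units; beyond the scatter) was brought about by replacing another five-membered ring with the 3-methyl-2,5-dioxoimidazolidin-4-yl group at the same place; compound 4 now removes that group again. Compound 1, which also carries a 2,4-dioxo-1,3-thiazolidin-5-yl ring, gives 1.24 h in this assay. An upward step is therefore expected for compound 4, as a 2.7-fold higher number from compound 3 to compound 4 (0.43 log units; beyond the scatter). Compound 4 is estimated at 1 h, between 0.4 h and 2.5 h.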

Compound 4, half-life: 1.87 h
Compound 4: the middle estimate sits 1.9-fold (0.27 log units) below what was measured; measured number inside the range.
By their numbers in this assay, from the lowest: compound 3; then compounds 1 and 4 (each within the scatter of the next). At a limit, above all of these: compound 2.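

In this assay, the step of a 5.0-fold higher number from compound 3 to compound 4 (0.70 log units; beyond the scatter) shows that the ring on this saturated chain carbon can move the half-life up as well as down, whereas the earlier step at this place went only downward. The step of an at least 1.6-fold lower number from compound 2 to compound 4 (0.20 log units; that floor lies within the scatter) gives only a floor, and that floor does not establish a real difference. Compound 2 stands at a limit and not at a number: the limit of > 3 h in this assay, at which 1 of the 4 values shown sits.

The compounds shown leave open whether the longer half-life goes with the ring sulfur or with the loss of the ring methyl, as the two groups differ in both at once. A 2,5-dioxoimidazolidin-4-yl ring without the methyl, on the same chain carbon, would separate these two changes.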